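Swapping the Pyridine Arm for Thiophene on a Shared Core

The compounds below may be only part of what the source reports. "The series", "measured", "known", "first", "only" and "open" are said of these compounds alone.

Compound 1, with the structure `Oc1cccc(-c2cc(-c3ccncc3)nc(-c3ccccc3Cl)c2)c1`, carries a 3-hydroxyphenyl group, a 2-chlorophenyl group and a pyridin-4-yl group around one shared core. Two close relatives share that core: compound 2, `Oc1cccc(-c2cc(-c3ccncc3)nc(-c3ccc(Cl)cc3)c2)c1`, where the chlorine sits on the 4-position of its phenyl ring, and compound 3, `Oc1ccc(-c2cc(-c3ccncc3)nc(-c3ccccc3Cl)c2)cc1`, where the hydroxyl sits on the 4-position of its phenyl ring. In an ADME assay on HEK293 cells (Homo sapiens) for cytotoxicity, read by CCK-8 assay and cell counting, with a stated time of 2 days (a higher number here means a weaker inhibitor, a lower number a stronger inhibitor), compound 2 gives 2890 nM. In this assay, among the compounds with values here, compound 1 gives "not determined" (no result reported), and compound 3 gives "not determined" (no result reported), so compound 1 stands without a number of its own, and the only number available for this series comes from compound 2.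

Compound 4, `Oc1cccc(-c2cc(-c3cccs3)nc(-c3ccccc3Cl)c2)c1`, differs from compound 1 in a single place: thiophen-2-yl in place of pyridin-4-yl on an aromatic carbon. Within the data shown here, no measured pair in this assay shows what such a swap does. Among the measured compounds shown here, no step size can be read from the data, and the expectation is a step of no particular direction, within the scatter of repeated measurements around the one number seen.

On that basis compound 4 is expected to show roughly 3000 nM in this assay, with a plausible range from 800 nM to 12000 nM.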

Compound 4, half-maximal inhibitory concentration: 2600 nM
Beside the measured number, compound 4's estimate is 1.2-fold (0.06 log units) above it, within the range that was stated.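

Within the data shown here, compound 1 has no single number in this assay, so no step from it to compound 4 can be read. From the compounds shown here alone, what replacing pyridin-4-yl with thiophen-2-yl does to the value on this shared core therefore remains open. No measured evidence offers an explanation for the value of compound 4.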